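Three compounds at the assay limit; a fourth estimated

This account rests on a few compounds, and the source may have more. Where it says the series, first, only, none or still open, it means among the compounds named here.

Measured so far:
- compound 1 `COc1ccccc1-n1nncc1CN1C(=O)C2(C(C#N)=C(N)Oc3c2c2nc4ccccc4nc2c2ccccc32)c2ccccc21`: in an ADME assay on HUVEC cells (Homo sapiens) for antiproliferative activity, read by MTT assay, with a stated time of 48 h (a lower number here means a stronger inhibitor, a higher number a weaker inhibitor), compound 1 gives > 50000 nM, a limit of the assay.
- compound 2 `CCOc1ccc(-n2nncc2CN2C(=O)C3(C(C#N)=C(N)Oc4c3c3nc5ccccc5nc3c3ccccc43)c3ccccc32)cc1`: compound 2 gives > 50000 nM, again a limit.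
- compound 3 `COc1ccccc1-n1nncc1CN1C(=O)C2(C(C#N)=C(N)Oc3c(N)cc4nc5ccccc5nc4c32)c2ccccc21`: compound 3 gives > 50000 nM, also a limit.

Compound 1 and compound 2 differ by 4-ethoxyphenyl in place of 2-methoxyphenyl on an aromatic nitrogen. The step that the two limits leave unreadable from compound 1 to compound 2 is not readable because both values sit at the limit of > 50000 nM in this assay, at which 3 of the 3 values shown sit. How the core of compound 1 differs from the core of compound 3 is not broken down here.

Compound 4 `CCOc1ccc(-n2nncc2CN2C(=O)C3(C(C#N)=C(N)Oc4c(N)cc5nc6ccccc6nc5c43)c3ccccc32)cc1` differs from compound 3 by 4-ethoxyphenyl in place of 2-methoxyphenyl on an aromatic nitrogen. The place is the same word for word, so this is the same change as between compound 1 and compound 2.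

The expected step is a step that the limit leaves unreadable from compound 3 to compound 4, resting on compound 3 sitting at the limit of > 50000 nM in this assay, at which 3 of the 3 values shown sit, and on the unreadable a step that the two limits leave unreadable from compound 1 to compound 2. Compound 4 is therefore expected to stay at the limit, estimated at 80000 nM.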

Compound 4, half-maximal inhibitory concentration: > 50000 nM
Compound 4 gave a limit, no number; the forecaster's own chance of this, stated with the estimate: 90%; the middle value lies beyond the limit too.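

Compound 3 and compound 4 both stand at a limit of the assay, not at a number, so no step between them can be read: the limit of > 50000 nM in this assay, at which 4 of the 4 values shown sit.

The compounds shown leave open whether 4-ethoxyphenyl in place of 2-methoxyphenyl, or the difference between the two cores, changes the activity at all.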